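Adding a Hydroxy Group to a Tolerated Scaffold

The source may hold more compounds than are shown below. What is called first, only, known or untested is meant among the compounds shown, and "the series" means these compounds.

Compound 1, `Cc1cc(-c2ccc(F)nc2F)nn(Cc2ccc(Cl)cc2)c1=O`, is the starting point. In an ADME assay on HepG2 2.2.15 cells (Homo sapiens) for cytotoxicity, read by MTT assay, with a stated time of 8 days (a lower number here means that less compound is tolerated, a higher number that more compound is tolerated), compound 1 gives 83800 nM. Among the three measured compounds it holds the only plain number; the other two values sit at the limit of > 100000 nM in this assay, at which 2 of the 3 values shown sit. Compound 2, `Cc1nc(-c2ccc(F)nc2F)cn(Cc2ccc(Cl)cc2)c1=O`, reaches only a limit of the assay in this assay, recorded as > 100000 nM. Compound 3, `N#Cc1ccc(Cn2nc(-c3cc(Cl)c(NCCC(=O)O)nc3F)c3ccccc3c2=O)cc1`, likewise stops at a limit in this assay, recorded as > 100000 nM. No pair among these three differs in a single place, so no measured step exists to guide the change ahead.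

Compound 4, `O=c1c(CO)cc(-c2ccc(F)nc2F)nn1Cc1ccc(Cl)cc1`, has not yet been measured. It differs from compound 1 by hydroxy in place of hydrogen on a saturated chain carbon bound to an aromatic carbon. With nothing measured for comparison, the expectation rests on the change itself, a single added group. The step in this assay is expected to stay within the usual scatter, with no clear direction. Compound 4 is therefore estimated at 90000 nM, with a range from 40000 nM to 100000 nM. That estimate means an expected step of a 1.1-fold higher number from compound 1 to compound 4 (0.03 log units; within the scatter).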

Compound 4, half-maximal cytotoxic concentration: > 100000 nM
Compound 4 was reported as a limit; the forecaster's own chance of this, stated with the estimate: 45%; middle value at least 1.1-fold (0.04 log units) away from the limit.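

In this assay, putting hydroxy in place of hydrogen on the saturated chain carbon bound to an aromatic carbon, which turns methyl into hydroxymethyl, gives an at least 1.1-fold higher number from compound 1 to compound 4 (0.07 log units; that floor lies within the scatter). Among the compounds shown here, this is the first step measured at this position, and it shows that the position accepts the added oxygen with no sign of a lower number. The reading for compound 4 is a limit of the assay and not a number, so the true size of the step remains unknown, and compound 4 joins the compounds that stop there: the limit of > 100000 nM in this assay, at which 3 of the 4 values shown sit.

Going by these compounds, whether an amine, a carboxylic acid or a longer chain at this position would keep the number at that limit remains open. How much compound 4 is actually tolerated also stays unresolved, since its reading gives only a floor.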